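Adding a sec-butyl group to a weak compound

A few compounds are considered here, and "the series" means these few. Any claim that something is new, unique, unknown or untested is made for them only; others in the source may bear on it.

Among the measured compounds shown here, in a functional assay on MCF7 cells (Homo sapiens) for antiproliferative activity, read by MTT assay, with a stated time of 48 h (on this read-out higher numbers stand for weaker inhibition and lower numbers for stronger inhibition), compound 1 (`CC[C@@H](C)[C@H](NC(=O)c1ccc(Oc2nc3ccccc3nc2C)cc1)C(=O)O`) gives 35700 nM, the only true number so far. Compound 2 (`CC(C)(C)Nc1nc2ccccc2nc1Oc1ccc(C(=O)NCC(=O)O)cc1`) stands at > 50000 nM, which is a limit of the assay and not a number, and it marks the weak end of what has been seen. Compound 3 (`CC[C@@H](C)[C@H](NC(=O)c1ccc(Oc2nc3ccccc3nc2NC(C)(C)C)cc1)C(=O)O`) comes from compound 2 by a single change, (sec-butyl in place of hydrogen on a saturated chain carbon bound to an amide-type nitrogen and a carbonyl carbon). This turns carboxymethyl into 1-carboxy-2-methylbutyl. For the measured compounds named here, no measured pair shows what such a change does in this assay, so only a small gain in inhibition is expected, one that may not clear the usual scatter. The expected move is an at least 1.6-fold lower number from compound 2 to compound 3 (0.22 log units; that floor lies within the scatter). Going by the values given here, this estimate leans on compound 1 at 35700 nM as the one available number. For compound 3, the estimated value is 30000 nM, with an expected range of 12000 nM to 50000 nM.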

Compound 3, half-maximal inhibitory concentration: 11400 nM
For compound 3 the middle estimate is 2.6-fold (0.42 log units) above the measured one; the measured number lies below the stated range.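

In this assay, among the compounds shown here, sec-butyl in place of hydrogen on a saturated chain carbon bound to an amide-type nitrogen and a carbonyl carbon gives an at least 4.3-fold lower number from compound 2 to compound 3 (0.64 log units; beyond the scatter), the first reading of what this change can do. Compound 2 stands at a limit of the assay and not a number, so this step gives only a floor for the true change: the limit of > 50000 nM in this assay, at which 1 of the 3 values shown sits. With the 1-carboxy-2-methylbutyl group held constant, (tert-butyl)amino in place of methyl on an aromatic carbon gives a 3.1-fold lower number from compound 1 to compound 3 (0.50 log units; beyond the scatter), so a second place on the molecule also moves the number.

Each change rests on a single pair of compounds, so neither can be called a pattern. From the compounds shown here alone, whether methyl, isopropyl or benzyl at the same chain carbon would give a similar gain remains open, as does the effect of a plain amino group in place of (tert-butyl)amino.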